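The source may report more compounds than this note shows. Statements on the series, on what has been measured and on what is new or still open speak of the compounds shown alone.

Measured compounds:

compound 1, `CSc1nc(NCCCCCO)c2cccnc2n1` — > 100000 nM
compound 2, `CSc1nc(NCc2ccccc2)c2ccccc2n1` — 82300 nM
compound 3, `CSc1nc(NCc2ccccc2)c2cccnc2n1` — 51600 nM

All three were tested in a functional assay on HTB-54 cells (Homo sapiens) for cytotoxicity, read by MTT assay, with a stated time of 72 h; a higher number here means a weaker inhibitor of growth, a lower number a stronger inhibitor of growth. For compound 1 the result is a limit of this assay and not a number: > 100000 nM. Compound 2 gives 82300 nM and compound 3 gives 51600 nM; these two lie within the scatter of each other, so no order between them can be read. The cores of compound 2 and compound 3 differ, but that difference is not broken down here.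

Within the data shown here, the one change that can be followed is the step from compound 3 to compound 1: 4-hydroxybutyl in place of phenyl on a saturated chain carbon bound to a nitrogen on an aromatic ring. In this assay it gives an at least 1.9-fold higher number from compound 3 to compound 1 (0.28 log units; that floor lies within the scatter). That step is known only as a floor because of the limit of > 100000 nM in this assay, at which 1 of the 3 values shown sits.

The same change, made on the core of compound 2, leads to compound 4, `CSc1nc(NCCCCCO)c2ccccc2n1`, which has not yet been measured. The change is 4-hydroxybutyl in place of phenyl on a saturated chain carbon bound to a nitrogen on an aromatic ring, and the place is the same in both pairs. Since compound 1 reached the limit of the assay from the value of compound 3, compound 4 is expected to move in the same direction from compound 2, with an expected step of a 1.8-fold higher number from compound 2 to compound 4 (0.26 log units; within the scatter). Compound 4 is therefore estimated to give 150000 nM in this assay, with a range from 60000 nM to 400000 nM, and a fair chance that only a limit is reported.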

Compound 4, concentration for total growth inhibition: 71400 nM
Beside the measured number, compound 4's estimate is 2.1-fold (0.32 log units) above it; the range from low to high includes it.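

In this assay, placing 4-hydroxybutyl where phenyl stood on the core of compound 2 gives a 1.2-fold lower number from compound 2 to compound 4 (0.06 log units; within the scatter), so on this core the ring and the chain cannot be told apart. On the other core, compound 1 gives > 100000 nM, which is a limit of the assay and not a number, and the step leading to it is known only as a floor: the limit of > 100000 nM in this assay, at which 1 of the 4 values shown sits. Set side by side, the two steps neither show that the change carries over from one core to the other nor show that it fails to, since a true number for compound 1 could lie close to the limit or far beyond it: the same change on two cores in this assay, an at least 1.9-fold higher number (0.28 log units; that floor lies within the scatter) from compound 3 to compound 1 and a 1.2-fold lower number (0.06 log units; within the scatter) from compound 2 to compound 4; the limit leaves it open whether they differ.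

The compounds shown leave open how large the step on the core of compound 1 really is, and so whether the core alters the effect of this change at all. They also leave open whether a longer chain, or an amine or a carboxylic acid in place of the hydroxyl of 4-hydroxybutyl, would give a number that stands clear of the scatter from that of compound 2.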